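Aryl substituent survey on the urea series at the hormone receptor

This account rests on a few compounds, and the source may have more. Where it says the series, first, only, none or still open, it means among the compounds named here.

Measured compounds: compound 1 `CN1CCN(CCCN(C(=O)Nc2ccc(F)c(Cl)c2)C2CCc3ccccc3C2)CC1`, compound 2 `CN1CCN(CCCN(C(=O)Nc2ccc(F)c(Cl)c2)C2CCc3cc(C#N)ccc3C2)CC1`, compound 3 `COc1ccc2c(c1)CC(N(CCCN1CCN(C)CC1)C(=O)Nc1ccc(F)c(Cl)c1)CC2`.

In an assay on CHO cells for binding affinity to melanin-concentrating hormone receptor 1 (Homo sapiens) (a higher number here means a weaker inhibitor, a lower number a stronger inhibitor), compound 1 gives 380 nM, compound 2 gives 340 nM and compound 3 gives 92 nM, the lowest of the three. The steps of a 1.1-fold lower number from compound 1 to compound 2 (0.05 log units; within the scatter) and a 4.1-fold lower number from compound 1 to compound 3 (0.62 log units; beyond the scatter) show that only the methoxy substituent improved the number.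

Compound 4 `CN1CCN(CCCN(C(=O)Nc2ccc(F)c(Cl)c2)C2CCc3ccc(S(C)(=O)=O)cc3C2)CC1` carries methylsulfonyl in place of methoxy on an aromatic carbon. The cyano step from compound 1 to compound 2 bears most closely, since it too is a substituent other than methoxy on that ring and gave nothing beyond the scatter. The methoxy gain is therefore expected to be lost in part: a modestly higher number, a 2.7-fold higher number from compound 3 to compound 4 (0.43 log units; beyond the scatter), is estimated, giving compound 4 about 250 nM (range 90 nM to 700 nM).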

Compound 4, inhibition constant: 1300 nM
Compound 4: the middle estimate sits 5.2-fold (0.72 log units) below what was measured; the measured number lies above the stated range.
By their numbers in this assay, from the lowest: compound 3; then compounds 2 and 1 (each within the scatter of the next); then compound 4.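

In this assay a substituent at this position can do harm as well as good: methylsulfonyl gives a 14-fold higher number from compound 3 to compound 4 (1.15 log units; beyond the scatter) and also a 3.4-fold higher number from compound 1 to compound 4 (0.53 log units; beyond the scatter), a rise past the unsubstituted core that neither compound 2 nor compound 3 showed. Relative to hydrogen, the outcome here therefore runs in both directions, with methoxy lowering the number and methylsulfonyl raising it. Nothing available accounts for this divergence. Open, going by these compounds, is whether ethoxy, hydroxyl or an amine at this position would sit nearer methoxy or methylsulfonyl. Also open, on these data alone, is whether the methoxy gain persists with a different aryl group on the urea.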